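This account rests on a few compounds, and the source may have more. Where it says the series, first, only, none or still open, it means among the compounds named here.

Measured in a functional assay on the whole organism with Canis familiaris (Canis lupus familiaris) as the target; on this read-out lower numbers stand for an effect already at smaller amounts and higher numbers for an effect only at larger amounts of compound:
- compound 1 `Cn1cnc2c(SCC(O)CN3CCN(C(c4ccc(F)cc4)c4ccc(F)cc4)CC3)ncnc21`: 1.9 mg/kg
- compound 2 `O=S(=O)(O)OC(CSc1[nH]cnc2ncnc1-2)CN1CCN(C(c2ccc(F)cc2)c2ccc(F)cc2)CC1`: 0.26 mg/kg
- compound 3 `Fc1ccc(C(c2ccc(F)cc2)N2CCN(CCCSc3[nH]cnc4ncnc3-4)CC2)cc1`: 1.3 mg/kg

On this assay, compound 1 cannot be told apart from compound 3, since their numbers lie within the scatter of each other. Its number lies beyond the scatter above that of compound 2.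

The next structure is compound 4 `OC(COc1[nH]cnc2ncnc1-2)CN1CCN(C(c2ccc(F)cc2)c2ccc(F)cc2)CC1`. Its change from compound 1 is this: a group of 10 heavy atoms (5 carbon, 4 nitrogen, 1 oxygen; one five-membered aromatic ring with 2 hetero atoms, one six-membered aromatic ring with 2 hetero atoms) in place of a group of 11 heavy atoms (6 carbon, 4 nitrogen, 1 sulfur; one five-membered aromatic ring with 2 hetero atoms, one six-membered aromatic ring with 2 hetero atoms), on a saturated chain carbon, two bonds along the chain from an oxygen on a saturated carbon. The swap sits on a saturated chain carbon, two bonds along the chain from an oxygen on a saturated carbon.

Among the measured compounds shown here, the only measured step, a 5.0-fold higher number from compound 2 to compound 3 (0.70 log units; beyond the scatter), puts hydrogen in place of sulfooxy. It involves neither of the swapped groups, so it gives only a rough idea of how far a single change can move this read-out. For the measured compounds named here, no measured compound carries the entering group. With so little to go on, no step beyond the scatter is expected, and the estimated step is a 1.3-fold lower number from compound 1 to compound 4 (0.10 log units; within the scatter).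

Compound 4 is estimated at 1.5 mg/kg, with an expected range from 0.4 mg/kg to 5 mg/kg.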

Compound 4, dose for half-maximal effect: 0.72 mg/kg
Estimate against measurement, compound 4: 2.1-fold (0.32 log units) above; the range from low to high includes it.
By their numbers in this assay, from the lowest: compound 2; then compounds 4, 3 and 1 (each within the scatter of the next, the first and the last beyond it).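

In this assay, among the compounds shown here, a 2.6-fold lower number from compound 1 to compound 4 (0.42 log units; beyond the scatter) is the first measured step at this place, a saturated chain carbon two bonds along the chain from an oxygen on a saturated carbon, and it shows that the group held there can move the read-out beyond the scatter. The swap changes several things at once: oxygen enters where sulfur leaves, the carbon count goes from 6 to 5, hydrogen-bond donors go from 0 to 1, and acceptors go from 5 to 4, so the step cannot be assigned to any one of these. Nothing measured here explains the step.

The compounds shown do not separate the exchange of sulfur for oxygen from the other differences between the two groups. They also leave open how a group linked through an amine nitrogen would behave at this place.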